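The source may report more compounds than this note shows. Statements on the series, on what has been measured and on what is new or still open speak of the compounds shown alone.

Measured compounds:
Compound 1, `CC1=CC[C@@H]([C@@](C)(O)CCCC(C)(C)NC=S)CC1`, in a functional assay on K562 cells (Homo sapiens) for cytotoxicity, read by sulforhodamine B assay (on this read-out lower numbers stand for higher toxicity in this test and higher numbers for lower toxicity in this test), gives > 100000 nM, which is a limit of the assay rather than a number.
Compound 2, `CC1=CC[C@@H]([C@@](C)(O)CCCC(C)(C)NC(=S)NN)CC1`, in this assay gives 9580 nM.
Compound 3, `CC1=CC[C@@H]([C@@](C)(O)CCCC(C)(C)NC(=S)N/N=C\c2ccc(C)cc2)CC1`, in this assay gives > 100000 nM, again a limit rather than a number.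

Compound 3 therefore stands at the limit. Compound 1 sits there too (the limit of > 100000 nM in this assay, at which 2 of the 3 values shown sit), so only compound 2 gave a number. Compound 4, `CC1=CC[C@@H]([C@@](C)(O)CCCC(C)(C)NC(=S)N/N=C\c2ccc(N(C)C)cc2)CC1`, differs from compound 3 in one place: dimethylamino in place of methyl on an aromatic carbon. The two measured steps, an at least 10-fold lower number from compound 1 to compound 2 (1.01 log units; beyond the scatter) and an at least 10-fold higher number from compound 2 to compound 3 (1.01 log units; beyond the scatter), were both large, but both concern what hangs on the thiocarbonyl carbon or on the amide-type nitrogen, not a group on the aromatic ring, so neither speaks directly to the change leading to compound 4. Within the data shown here, with no measured step to lean on, compound 4 is expected to show no change beyond the scatter and to stay at the limit, the expected step being a step that the limit leaves unreadable from compound 3 to compound 4. For compound 4 the estimated value in this assay is 150000 nM, within 30000 nM to 600000 nM.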

Compound 4, concentration lethal to 50% of the cells: > 100000 nM
Compound 4 gave a limit, no number; the forecaster's own chance of this, stated with the estimate: 70%; the middle value lies beyond the limit too.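

In this assay compound 3 and compound 4 both give limits rather than numbers, so no step can be read between them: the limit of > 100000 nM in this assay, at which 3 of the 4 values shown sit.

The compounds shown leave open whether 4-(dimethylamino)phenyl in place of 4-methylphenyl changes toxicity in this test at all.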